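Three Ethers and a Free Hydroxyl on One Shared Core

The source may report more compounds than this note shows. Statements on the series, on what has been measured and on what is new or still open speak of the compounds shown alone.

Measured compounds:
- Compound 1, `CC(C)=CCC1Cc2c(O)cc(=O)n(CCCO)c2CC1(C)C`, gives 0%.
- Compound 2, `CCOc1cc(=O)n(CCCO)c2c1CC(CC=C(C)C)C(C)(C)C2`, gives 16.6%.
- Compound 3, `CC(C)=CCC1Cc2c(OCc3ccccc3)cc(=O)n(CCCO)c2CC1(C)C`, gives 11.1%.

These numbers come from a functional assay on PANC-1 cells (Homo sapiens) for inhibition, read by MTT assay, with a stated time of 24 h, tested at 10 uM; a higher number here means more inhibition at the concentration tested (going by the name of the read-out), a lower number less inhibition. Compound 3 stands second highest of the three: compound 2 is a number 5.5 percentage points lower from compound 2 to compound 3 (within the scatter), which is within the scatter, while the free hydroxyl of compound 1 sits lowest, as the step of a number 11.1 percentage points higher from compound 1 to compound 3 (beyond the scatter) shows, beyond the scatter.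

Compound 4, `CC(C)=CCOc1cc(=O)n(CCCO)c2c1CC(CC=C(C)C)C(C)(C)C2`, has not yet been measured. It differs from compound 3 in one place: 2-methylprop-1-en-1-yl in place of phenyl on a saturated chain carbon bound to an oxygen on an aromatic ring. Within the data shown here, the step that bears most on this is the one from compound 2 to compound 3, where the group on that same saturated chain carbon was also changed, and it was a number 5.5 percentage points lower from compound 2 to compound 3 (within the scatter), within the scatter. Both ethers, compounds 2 and 3, lie modestly above compound 1, so the ether itself seems to carry the difference rather than the group placed on it. No step beyond the scatter is therefore expected in this assay .

Compound 4 is expected to give about 13%, with a range from 0% to 30%. That estimate corresponds to an expected step of a number 1.9 percentage points higher from compound 3 to compound 4 (within the scatter).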

Compound 4, a percentage reported as inhibition, at one concentration (the size of the read-out at that concentration, not a potency): 7.5%
Compound 4: the middle estimate sits 5.5 percentage points above what was measured, within the range that was stated.
By their numbers in this assay, from the lowest: compounds 1, 4, 3 and 2 (each within the scatter of the next, the first and the last beyond it).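

In this assay, changing the group on this oxygen gives a number 3.6 percentage points lower from compound 3 to compound 4 (within the scatter) and a number 9.1 percentage points lower from compound 2 to compound 4 (within the scatter), so ethyl, benzyl and 3-methylbut-2-en-1-yl cannot be told apart here, even with an open chain holding a double bond in place of a phenyl ring. The new point lies in the comparison with the free hydroxyl: the step is a number 7.5 percentage points higher from compound 1 to compound 4 (within the scatter), so this ether, unlike those of compound 2 and compound 3, does not clear the scatter, and the idea that any ether on this oxygen sets a compound apart from compound 1 no longer holds. No measurement at hand explains these small differences.

From the compounds shown here alone, it remains open whether any group on this oxygen can lift the number far beyond the scatter. An ether carrying an amine, a carboxylic acid or a longer chain such as octyl would probe that.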